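A few compounds are considered here, and "the series" means these few. Any claim that something is new, unique, unknown or untested is made for them only; others in the source may bear on it.

Compound 1 `Oc1ccc(-c2cc(-c3ccc(O)cc3)nc(-c3ccc(O)cc3)c2)cc1` and compound 2 `Oc1ccc(-c2cc(-c3cccc(O)c3)cc(-c3cccc(O)c3)n2)cc1` share a core, a six-membered aromatic ring with one nitrogen, carrying three hydroxyphenyl groups. Both were tested in a functional assay on T47D cells (Homo sapiens) for cytotoxicity, read by CCK-8 assay, with a stated time of 4 days; a higher number here means a weaker inhibitor, a lower number a stronger inhibitor. In this assay compound 1 gives 4270 nM. Compound 2 gives 3920 nM, and the two numbers lie within the usual scatter of each other, so on this evidence the two compounds cannot be told apart.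

Compound 3 `Oc1ccc(-c2cc(-c3cccc(O)c3)cc(-c3ccc(O)cc3)n2)cc1` has not yet been measured in this assay. It differs from compound 2 in one place: 4-hydroxyphenyl in place of 3-hydroxyphenyl on an aromatic carbon. The two compounds have the same atoms, joined differently; compound 3 carries two 4-hydroxyphenyl groups and one 3-hydroxyphenyl group, and so sits between compound 1, with three 4-hydroxyphenyl groups, and compound 2, with one.

Because compound 1 gives 4270 nM and compound 2 gives 3920 nM, the swap of a 3-hydroxyphenyl for a 4-hydroxyphenyl appears to make no difference beyond the scatter. The step from compound 2 to compound 3 is therefore expected to be a 1.0-fold higher number from compound 2 to compound 3 (0.02 log units; within the scatter), no change beyond the scatter. Compound 3 is expected to give about 4100 nM, most likely between 2000 nM and 8500 nM.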

Compound 3, half-maximal inhibitory concentration: 4070 nM
Beside the measured number, compound 3's estimate is 1.0-fold (0.00 log units) above it; the measured number falls inside the stated range.
By their numbers in this assay, from the lowest: compounds 2, 3 and 1 (each within the scatter of the next).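

In this assay, the swap to 4-hydroxyphenyl from 3-hydroxyphenyl on the aromatic carbon next to the ring nitrogen can now be read on its own, as a 1.0-fold higher number from compound 2 to compound 3 (0.02 log units; within the scatter) and no more than that. The reverse kind of swap on an aromatic carbon reads as a 1.0-fold lower number from compound 1 to compound 3 (0.02 log units; within the scatter) and so also stays inside the scatter, whereas compound 1 and compound 2 differ in more than one place and could not show what a single swap does. So for these three compounds, each single exchange between the two hydroxyphenyl groups leaves the number where it was, and no supporting measurement is available to explain why.

As far as these compounds go, what remains open is whether this position responds at all to something other than a hydroxyphenyl group, such as a 2-hydroxyphenyl, a methoxyphenyl or an aminophenyl group, or a phenyl ring carrying a carboxylic acid. From the compounds shown here alone, it is also open whether an unsubstituted phenyl group here, with no hydroxyl at all, would give a number beyond the scatter.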